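Triazolothiadiazine series: aryl substituent swap on the imine carbon

The source may hold more compounds than are shown below. What is called first, only, known or untested is meant among the compounds shown, and "the series" means these compounds.

Measured so far in a functional assay on HCT-116 cells (Homo sapiens) for inhibition, read by sulforhodamine B assay, with a stated time of 72 h; a higher number here means a weaker inhibitor, a lower number a stronger inhibitor:
- compound 1 `CC(c1ccc(-c2ccccc2)c(F)c1)c1nnc2n1N=C(c1ccc(Cl)cc1Cl)CS2` gives 6900 nM
- compound 2 `CC(C)Cc1ccc(C(C)c2nnc3n2N=C(c2ccc(OC(F)(F)F)cc2)CS3)cc1` gives 3000 nM
- compound 3 `COc1ccc(C2=Nn3c(nnc3C(C)c3ccc(-c4ccccc4)c(F)c3)SC2)cc1` gives 4400 nM

Compound 2 has the lowest number of the three. Its gap to compound 3 is within the scatter, so the two cannot be ordered; its gap to compound 1 is beyond the scatter.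

Within the data shown here, the only single-point step among the measured compounds is a 1.6-fold lower number from compound 1 to compound 3 (0.20 log units; within the scatter), a change of the aryl group on the carbon with a double bond to nitrogen that left the number within the scatter.

Compound 4 `CC(C)Cc1ccc(C(C)c2nnc3n2N=C(c2ccc(C(F)(F)F)cc2)CS3)cc1` differs from compound 2 as follows: trifluoromethyl in place of trifluoromethoxy on an aromatic carbon. Among the measured compounds shown here, no measured pair isolates this exchange; the one step that touches this aryl group, from compound 1 to compound 3, was within the scatter. On that basis no step beyond the scatter is expected in this assay, in either direction. Compound 4 is therefore estimated at 3000 nM, with a range of 1500 nM to 6500 nM, corresponding to an expected step of no change at the digits printed from compound 2 to compound 4 (within the scatter).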

Compound 4, half-maximal inhibitory concentration: 6500 nM
Estimate against measurement, compound 4: 2.2-fold (0.34 log units) below, within the range that was stated.
By their numbers in this assay, from the lowest: compounds 2, 3, 4 and 1 (each within the scatter of the next, the first and the last beyond it).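

Trifluoromethyl in place of trifluoromethoxy gives a 2.2-fold higher number from compound 2 to compound 4 (0.34 log units; beyond the scatter) in this assay, the first single-point step in the series to lie beyond the scatter, though only modestly. The earlier step on this aryl group, 4-methoxyphenyl in place of 2,4-dichlorophenyl, stayed within the scatter, whereas here the number moves when the group on an aromatic carbon, para to a large group, loses only its oxygen atom. The data offer no measured explanation for this step.

Among these compounds, whether the exchange gives a similar step when the core carries the other side group, the one shared by compound 1 and compound 3, stays open. Also open, from the compounds shown here alone, is how the number responds at this position to an amine, a carboxylic acid or a longer alkyl chain.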